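This account rests on a few compounds, and the source may have more. Where it says the series, first, only, none or still open, it means among the compounds named here.

In a functional assay on HL-60 cells (Homo sapiens) for cytotoxicity, read by MTT assay, with a stated time of 72 h (on this read-out higher numbers stand for weaker inhibition and lower numbers for stronger inhibition), compound 1 `O=S(=O)(c1ccccc1)c1nc2ccccc2nc1Nc1ccccc1` gives 140 nM. Compound 2 `COc1ccc(Nc2nc3ccccc3nc2S(=O)(=O)c2ccccc2)cc1` carries methoxy in place of hydrogen on an aromatic carbon, and in this assay compound 2 gives 640 nM, a step of a 4.6-fold higher number from compound 1 to compound 2 (0.66 log units; beyond the scatter). Compound 3 `COc1ccc(S(=O)(=O)c2nc3ccccc3nc2Nc2cc(OC)cc(OC)c2)cc1` differs from compound 1 in more than one place, and the difference between the two cores is not broken down here; in this assay compound 3 gives 1710 nM, the highest of the three numbers, with compound 2 the nearest to it. Compound 4 `COc1ccc(S(=O)(=O)c2nc3ccccc3nc2Nc2cc(OC)c(OC)c(OC)c2)cc1` is not yet measured; it differs from compound 3 by methoxy in place of hydrogen on an aromatic carbon. This is the same kind of change as that from compound 1 to compound 2, though here the entering group sits ortho to two methoxy groups as well as para to a large group. Because the earlier step of a 4.6-fold higher number from compound 1 to compound 2 (0.66 log units; beyond the scatter) raised the number, a step of a 1.8-fold higher number from compound 3 to compound 4 (0.24 log units; within the scatter) is expected here. In this assay compound 4 is estimated at 3000 nM, between 1000 nM and 9000 nM.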

Compound 4, half-maximal inhibitory concentration: 680 nM
The estimate for compound 4 lay 4.4-fold (0.64 log units) above the measured number; the measured number lies below the stated range.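

In this assay, methoxy in place of hydrogen on an aromatic carbon gives a 2.5-fold lower number from compound 3 to compound 4 (0.40 log units; beyond the scatter). Going by these compounds alone, the change therefore does not carry from one core to the other with a fixed size, or even a fixed direction: the same change on two cores in this assay, a 4.6-fold higher number (0.66 log units; beyond the scatter) from compound 1 to compound 2 and a 2.5-fold lower number (0.40 log units; beyond the scatter) from compound 3 to compound 4, 11-fold (1.06 log units) apart, beyond the scatter of two such steps This shows that the outcome depends on the setting, but with only two pairs, which differ in more than one feature, it does not show which feature of the core turns the step around, nor why.

The compounds shown leave open whether an amine or a carboxylic acid in the same place would follow either methoxy step. Going by these compounds, it also remains open how the step would run on a core carrying fewer methoxy groups than compound 3.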